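This account rests on a few compounds, and the source may have more. Where it says the series, first, only, none or still open, it means among the compounds named here.

Compound 1 `COc1cc2c(Oc3ccc(NC(=O)c4nn(-c5ccccc5)c(=O)c5ccccc45)cc3F)ccnc2cc1OCCCN1CCCC1` was tested in a functional assay on MKN-45 cells (Homo sapiens) for cytotoxicity, read by MTT assay, with a stated time of 72 h (a lower number here means a stronger inhibitor, a higher number a weaker inhibitor), where compound 1 gives 530 nM. Among the three compounds measured so far it stands second highest, which here means second weakest. Its two neighbours differ from it only in the ring attached to the aromatic nitrogen of the shared core. Compound 2 `COc1cc2c(Oc3ccc(NC(=O)c4nn(-c5ccccc5F)c(=O)c5ccccc45)cc3F)ccnc2cc1OCCCN1CCCC1` gives 140 nM in this assay, a change of a 3.8-fold lower number from compound 1 to compound 2 (0.58 log units; beyond the scatter). Compound 3 `COc1cc2c(Oc3ccc(NC(=O)c4nn(-c5ccc([N+](=O)[O-])cc5)c(=O)c5ccccc45)cc3F)ccnc2cc1OCCCN1CCCC1` gives 1620 nM in this assay, a change of a 3.1-fold higher number from compound 1 to compound 3 (0.49 log units; beyond the scatter). Between those two the gap is a 12-fold higher number from compound 2 to compound 3 (1.06 log units; beyond the scatter).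

Compound 4 `COc1cc2c(Oc3ccc(NC(=O)c4nn(-c5ccccc5)c(=O)c5ccccc45)cc3F)ccnc2cc1OCCCN1CCCCC1` differs from compound 1 in a different part of the molecule: piperidin-1-yl in place of pyrrolidin-1-yl on a saturated chain carbon, three bonds along the chain from an oxygen on an aromatic ring. The ring at the end of the chain grows by one member, while the rest of the molecule is unchanged. Among the compounds with values here, none of the measured steps touches this chain end; all of them change the aromatic ring on the nitrogen, so they give no direct guide to what the larger saturated ring does. In the absence of a comparable step, the expectation is a small change, within the scatter, from compound 1 to compound 4 in this assay, that is a 1.1-fold lower number from compound 1 to compound 4 (0.03 log units; within the scatter). Compound 4 is therefore estimated at 500 nM, with a likely range from 230 nM to 1100 nM.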

Compound 4, half-maximal inhibitory concentration: 590 nM
For compound 4 the middle estimate is 1.2-fold (0.07 log units) below the measured one; the measured number falls inside the stated range.
By their numbers in this assay, from the lowest: compound 2; then compounds 1 and 4 (each within the scatter of the next); then compound 3.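

Putting piperidin-1-yl in place of pyrrolidin-1-yl at the end of the chain gives a 1.1-fold higher number from compound 1 to compound 4 (0.05 log units; within the scatter) in this assay, so the two compounds cannot be told apart in this test even though the five-membered ring has become a six-membered one. Within the data shown here, this is the first reading from the chain end: the earlier steps all changed the aromatic ring on the nitrogen, and each of them lay beyond the scatter, whereas this single swap at the chain end does not. Nothing available here explains why these two saturated rings read alike, and a single pair cannot show how much change this position will accept in general.

From the compounds shown here alone, it remains open what a morpholine ring or an open-chain dimethylamino group would do at this same chain end, and whether a longer chain than 3-(piperidin-1-yl)propyl would give a similar number. Going by these compounds, it is also open whether the same ring swap would read alike on compound 2, which carries the 2-fluorophenyl group on the aromatic nitrogen.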